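The compounds below may be only part of what the source reports. "The series", "measured", "known", "first", "only" and "open" are said of these compounds alone.

Measured compounds:
- Compound 1, `COc1cc(-c2cccc3nc(-c4ccccc4)oc23)cc(OC)c1OC`. In a functional assay on MCF7 cells (Homo sapiens) for antiproliferative activity, read by MTT assay, with a stated time of 48 h (a higher number here means a weaker inhibitor, a lower number a stronger inhibitor), compound 1 gives > 25000 nM, a limit of the assay rather than a number.
- Compound 2, `COc1ccc(-c2nc3cccc(-c4cc(OC)c(OC)c(OC)c4)c3o2)cc1OC`. Compound 2 gives > 25000 nM, again a limit.
- Compound 3, `COc1cc(-c2cccc3nc(-c4cccc(Br)c4)oc23)cc(OC)c1OC`. Compound 3 gives > 25000 nM, also a limit.

Compound 1 therefore stands at the limit of this assay, and so do the other two measured compounds: the limit of > 25000 nM in this assay, at which 3 of the 3 values shown sit. None of the three comparisons can be read as a step of any size, since a step that the two limits leave unreadable from compound 1 to compound 2, a step that the two limits leave unreadable from compound 1 to compound 3 and a step that the two limits leave unreadable from compound 2 to compound 3 all run between two limits.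

The next compound is compound 4, `COc1cc(-c2cccc3nc(-c4cccc(N)c4)oc23)cc(OC)c1OC`. It differs from compound 1 as follows: amino in place of hydrogen on an aromatic carbon; the new group sits on an aromatic carbon of a six-membered aromatic ring of carbon only, meta to a large group. Within the data shown here, no measured step bears on this change, and the bromo in place of hydrogen step that sits at the same position gives no readable size. With nothing to read, no step beyond the scatter is expected in either direction, and compound 4 is estimated to remain at or near the limit: a step that the limit leaves unreadable from compound 1 to compound 4, giving an expected 30000 nM with a range of 5000 nM to 100000 nM.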

Compound 4, half-maximal inhibitory concentration: > 25000 nM
Compound 4 was reported as a limit; the forecaster's own chance of this, stated with the estimate: 70%; the middle value is on the limit's open side.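

Among these compounds, compound 4 gives > 25000 nM in this assay, which is a limit, so no step from compound 1, compound 2 or compound 3 to compound 4 can be read. The compounds shown leave open which change to the shared core, if any, would give a measurable value.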